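The compounds below may be only part of what the source reports. "The series", "measured", "known", "first", "only" and "open" are said of these compounds alone.

Measured compounds:
compound 1 `C=C(CC)C(=O)c1ccc(OCC(=O)Nc2nc3ccccc3s2)c(Cl)c1Cl` — 1500 nM
compound 2 `C=C(CC)C(=O)c1ccc(OCC(=O)Nc2ccc3c(C)cc(=O)oc3c2)c(Cl)c1Cl` — 2800 nM

In a functional assay on CLL cells (Homo sapiens) for cytotoxicity, read by MTT assay, with a stated time of 48 h (a higher number here means that more compound is needed for the effect, a lower number that less compound is needed), compound 1 stands at the lowest of the two numbers, and compound 2 lies within the usual scatter of it, so the two cannot be told apart. Compound 3 `C=C(CC)C(=O)c1ccc(OCC(=O)NCCO)c(Cl)c1Cl` has not been measured. It differs from compound 1 in one place: 2-hydroxyethyl in place of 1,3-benzothiazol-2-yl on an amide-type nitrogen. Among the measured compounds shown here, no step between measured compounds covers a change of this kind, so its size is only expected, not derived. The account expects the number to rise, a step of a 2.7-fold higher number from compound 1 to compound 3 (0.43 log units; beyond the scatter) beyond the scatter. For compound 3 in this assay the estimate is 4000 nM, with a range from 1500 nM to 12000 nM.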

Compound 3, half-maximal effective concentration: > 25000 nM
Compound 3: a limit, no number; the forecaster's own chance of this, stated with the estimate: 15%; middle value at least 6.2-fold (0.79 log units) from the limit.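

Compound 1 and compound 2 lay within the scatter of each other, so the amide-type nitrogen had looked tolerant of change. In this assay, compound 3 gives > 25000 nM, a limit of the assay and not a number. Putting 2-hydroxyethyl in place of 1,3-benzothiazol-2-yl at this position gives an at least 16-fold higher number from compound 1 to compound 3 (1.22 log units; beyond the scatter), so this substituent does matter. From the compounds shown here alone, whether the step follows the loss of the rings or the entry of the hydroxyl stays open. Also open, going by these compounds, is how a phenyl ring or a plain ethyl chain on that nitrogen would read.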